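The compounds below may be only part of what the source reports. "The series", "measured", "known", "first", "only" and "open" are said of these compounds alone.

Within the data shown here, in a functional assay on U-87MG ATCC cells (Homo sapiens) for inhibition (on this read-out higher numbers stand for weaker inhibition and lower numbers for stronger inhibition), compound 2 `COc1cc(/C=C/C(=O)c2cccc(NC(=O)C(C)C)c2)ccc1O` gives 8.31 ug/mL, the lower of the two numbers so far, while compound 1 `COc1cc(/C=C/C(=O)c2cccc(NC(=O)c3c(Cl)cccc3Cl)c2)ccc1O` gives 17.8 ug/mL (the higher). Compound 3 `COc1cc(/C=C/C(=O)c2cccc(NC(=O)c3ccccc3)c2)ccc1O` has phenyl in place of isopropyl on a carbonyl carbon (same core). Among the measured compounds shown here, the only measured step at that place is a 2.1-fold lower number from compound 1 to compound 2 (0.33 log units; beyond the scatter) with isopropyl in place of 2,6-dichlorophenyl, a modest one. Phenyl is not 2,6-dichlorophenyl, so only part of that step is expected to reverse in this assay as a small rise, probably within the scatter: a 1.5-fold higher number from compound 2 to compound 3 (0.18 log units; within the scatter) (estimated). For compound 3 the expected value is 12.5 ug/mL (estimated range 6 ug/mL to 25 ug/mL).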

Compound 3, half-maximal inhibitory concentration: 8.82 ug/mL
Compound 3: middle estimate off by 1.4-fold (0.15 log units), on the high side, within the range that was stated.
By their numbers in this assay, from the lowest: compounds 2, 3 and 1 (each within the scatter of the next, the first and the last beyond it).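

In this assay the change from isopropyl to phenyl on this carbonyl carbon gives a 1.1-fold higher number from compound 2 to compound 3 (0.03 log units; within the scatter) and so separates neither group from the other at this position. Phenyl in place of 2,6-dichlorophenyl gives a 2.0-fold lower number from compound 1 to compound 3 (0.30 log units; within the scatter) and so, unlike isopropyl in the same comparison, does not clear the scatter. Nothing available explains these results.

On these data alone, whether a methyl group, a longer chain, an amine or a carboxylic acid on this carbonyl carbon would keep the number in the same range stays open. Also open, as far as these compounds go, is whether a single chlorine on the phenyl ring would be enough to shift it.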